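Compound 3: a swapped aryl group at the solubility limit

The source may hold more compounds than are shown below. What is called first, only, known or untested is meant among the compounds shown, and "the series" means these compounds.

Measured in a physicochemical assay for solubility; on this read-out higher numbers stand for higher solubility and lower numbers for lower solubility:
- compound 1 `O=C(O)c1ccc(C(=O)/C(=C\c2cc([N+](=O)[O-])ccc2F)SCc2ccc(Br)cc2)cc1`: < 1000 ug/mL
- compound 2 `O=C(O)c1ccc(C(=O)/C(=C\c2ccc(Cl)c([N+](=O)[O-])c2)S(=O)(=O)Cc2ccc(Br)cc2)cc1`: < 1000 ug/mL

Both entries are limits of the assay, not numbers. For the measured compounds named here, compound 1 therefore has no numeric position, and the only measured information is the limit of < 1000 ug/mL in this assay, at which 2 of the 2 values shown sit. Compound 3 `O=C(O)c1ccc(C(=O)/C(=C\c2ccc(O)c(Br)c2)SCc2ccc(Br)cc2)cc1` keeps the core of compound 1 and carries 3-bromo-4-hydroxyphenyl in place of 2-fluoro-5-nitrophenyl on a double-bonded chain carbon bound to a double-bonded chain carbon. No measured step sizes this change, so no step beyond the scatter is expected in this assay, and neither direction is favoured. Compound 3 is also expected to be reported as a limit rather than a number. If a number is obtained, the estimate for compound 3 is 600 ug/mL, with an expected range from 150 ug/mL to 1000 ug/mL. This corresponds to an expected step that the limit leaves unreadable from compound 1 to compound 3.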

Compound 3, solubility: < 1000 ug/mL
Compound 3 gave a limit, no number; the forecaster's own chance of this, stated with the estimate: 80%; the middle value lies beyond the limit too.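

In this assay, no step can be read from compound 1 to compound 3, as both entries are limits and not numbers: the limit of < 1000 ug/mL in this assay, at which 3 of the 3 values shown sit.

The compounds shown leave open where compound 1, compound 2 and compound 3 lie numerically, and what size or direction 3-bromo-4-hydroxyphenyl in place of 2-fluoro-5-nitrophenyl brings in this assay.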